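The source may report more compounds than this note shows. Statements on the series, on what has been measured and on what is new or still open speak of the compounds shown alone.

Measured compounds in a functional assay on MCF7 cells (Homo sapiens) for cytotoxicity, read by MTT assay, with a stated time of 72 h; a higher number here means a weaker inhibitor, a lower number a stronger inhibitor:
- compound 1 `O=C(NCc1ccc(F)cc1)c1nc(Br)c2cccnc2c1NCc1ccccc1` gives "not determined" (no result reported)
- compound 2 `COC(=O)c1nc(Br)c2cccnc2c1N[C@H]1CC[C@H](N)CC1` gives > 20000 nM
- compound 3 `N[C@H]1CC[C@H](Nc2c(C(=O)NCc3ccc(Cl)cc3Cl)nc(Br)c3cccnc23)CC1` gives "not determined" (no result reported)

Compound 1 stands without a number in this assay, as does compound 3. For the measured compounds named here, the only entry with a reading is compound 2, and that reading is a limit of the assay rather than a number: compound 2 gives > 20000 nM. Going by the values given here, no step between two measured compounds can be drawn from these three entries, so there is no measured step on which to rest an expectation. The one fact on record is the limit of > 20000 nM in this assay, at which 1 of the 3 values shown sits.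

The step from compound 1 to compound 4 `NCCCNc1c(C(=O)NCc2ccc(F)cc2)nc(Br)c2cccnc12` is the change (2-aminoethyl in place of phenyl on a saturated chain carbon bound to a nitrogen on an aromatic ring). The shared core, the bromine and the amide with its 4-fluorobenzyl group are kept; what moves is the group on the saturated chain carbon bound to the nitrogen on the aromatic ring, from phenyl to 2-aminoethyl.

Among the compounds with values here, with no measured step in this assay and no number for compound 1, the size and direction of this step cannot be anchored. The only numerical anchor in the series is the limit reached by compound 2, so for compound 4 a weak reading is expected, with a considerable chance of a limit again. The estimate for compound 4 in this assay is 15000 nM, within 3000 nM to 60000 nM.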

Compound 4, half-maximal inhibitory concentration: 6000 nM
For compound 4 the middle estimate is 2.5-fold (0.40 log units) above the measured one; measured number inside the range.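

In this assay compound 4 gives 6000 nM, but compound 1 has no single number to set against it, so no new step can be read. The compounds shown leave open how large the change from phenyl to 2-aminoethyl is in this assay, and in which direction it runs.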